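This account rests on a few compounds, and the source may have more. Where it says the series, first, only, none or still open, it means among the compounds named here.

Compound 2 `O=S(=O)(Nc1cccc2c1CCCC2c1c[nH]cn1)C1CC1` gives 2690 nM in an assay on isolated protein for binding affinity to Alpha-1D adrenergic receptor (Rattus norvegicus), read by radioligand binding (on this read-out higher numbers stand for weaker inhibition and lower numbers for stronger inhibition), the higher of the two numbers at hand; compound 1 `CN(c1cccc2c1CCCC2c1c[nH]cn1)S(C)(=O)=O` gives 708 nM, and the step is a 3.8-fold higher number from compound 1 to compound 2 (0.58 log units; beyond the scatter). Compound 3 `CN(C)S(=O)(=O)Nc1cccc2c1CCCC2c1c[nH]cn1` differs from compound 2 by dimethylamino in place of cyclopropyl on a sulfonyl sulfur. Among the compounds with values here, only the step from compound 1 to compound 2 bears on this change, and it altered the sulfonyl group together with the nitrogen substituent, so it offers loose guidance; no measured step exchanges a carbon group for dimethylamino on the sulfonyl sulfur. Compound 3 is therefore expected to show a step of a 1.2-fold lower number from compound 2 to compound 3 (0.09 log units; within the scatter), within the scatter, with an estimate of 2200 nM and a range from 700 nM to 7000 nM.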

Compound 3, inhibition constant: 1580 nM
Estimate against measurement, compound 3: 1.4-fold (0.14 log units) above, and the stated range covers the measured number.
By their numbers in this assay, from the lowest: compound 1; then compounds 3 and 2 (each within the scatter of the next).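

In this assay, the step with dimethylamino in place of cyclopropyl on a sulfonyl sulfur is a 1.7-fold lower number from compound 2 to compound 3 (0.23 log units; within the scatter), so the two groups cannot be told apart at this place. With (dimethylsulfamoyl)amino in place of methyl(methylsulfonyl)amino, the step is a 2.2-fold higher number from compound 1 to compound 3 (0.35 log units; beyond the scatter), and compound 1 keeps the lowest number of the three. Nothing at hand explains these results.

As far as these compounds go, what a morpholine or a longer chain on the sulfonyl sulfur would give remains open. So does the effect of a methyl on the sulfonamide nitrogen of compound 3.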